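This account rests on a few compounds, and the source may have more. Where it says the series, first, only, none or still open, it means among the compounds named here.

In an ADME assay on HeLa cells (Homo sapiens) for cytotoxicity, read by sulforhodamine B assay, with a stated time of 48 h, tested at 10 uM (on this read-out lower numbers stand for less inhibition and higher numbers for more inhibition at the one concentration tested (going by the name of the read-out)), compound 2 `CCOC(=O)c1cn(C(c2ccccc2)c2cc3cc(Br)ccc3nc2OC)nn1` gives -3.67%. Its only neighbour on the numbers shown is compound 1 `CCCCCCc1cn(C(c2ccccc2)c2cc3cc(Br)ccc3nc2OC)nn1`, which in this assay gives -0.97%; the two sit within the scatter of each other, and the one measured step, a number 2.7 percentage points lower from compound 1 to compound 2 (within the scatter), runs through the same position of the shared core. Compound 3 `COc1nc2ccc(Br)cc2cc1C(c1ccccc1)n1cc(-c2cccc(F)c2)nn1` is the next compound in this series and differs from compound 2 by 3-fluorophenyl in place of ethoxycarbonyl on an aromatic carbon. Going by the values given here, the single step that bears on this change, the exchange of a hexyl for an ethoxycarbonyl at that same carbon, moved the inhibition by no more than the scatter, and nothing in the two numbers points in either direction. For compound 3 in this assay an inhibition of -2% is therefore expected, with a range from -12% to 8%. The step this expectation means is a number 1.7 percentage points higher from compound 2 to compound 3 (within the scatter), no change beyond the scatter.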

Compound 3, a percentage reported as inhibition, at one concentration (the size of the read-out at that concentration, not a potency): 9.04%
For compound 3 the middle estimate is 11 percentage points below the measured one, outside the stated range (above it).
By their numbers in this assay, from the lowest: compounds 2, 1 and 3 (each within the scatter of the next, the first and the last beyond it).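

Going by these compounds alone, at this carbon of the five-membered aromatic ring, the one earlier step had stayed within the scatter in this assay, but 3-fluorophenyl in place of ethoxycarbonyl gives a number 12.7 percentage points higher from compound 2 to compound 3 (beyond the scatter), the first sign that the group here can shift the read-out, if only modestly. Against hexyl, the same 3-fluorophenyl gives a number 10 percentage points higher from compound 1 to compound 3 (within the scatter), so the change stands out only against ethoxycarbonyl, and hexyl cannot be told apart from either of the other two groups. Nothing measured here accounts for the step.

On these data alone, it remains open whether the aromatic ring or its fluorine carries the step, which a plain phenyl at this carbon would help to separate. As far as these compounds go, how a carboxylic acid, an amine or a longer chain would read at the same position also remains open.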